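This account rests on a few compounds, and the source may have more. Where it says the series, first, only, none or still open, it means among the compounds named here.

Measured in a functional assay on MCF7 cells (Homo sapiens), read by MTT assay, with a stated time of 48 h; a lower number here means a stronger inhibitor, a higher number a weaker inhibitor:

Compound 1 `CCN(CC)CCCNC(=O)c1ccc(C(CC)(CC)c2ccc(OCC(=O)C(C)(C)C)c(C)c2)n1CC`: 530 nM
Compound 2 `CCn1c(C(=O)NCCN(C)C)ccc1C(CC)(CC)c1ccc(OCC(O)C(C)(C)C)c(C)c1`: 660 nM
Compound 3 `CCn1c(C(=O)NCCCN(C)C)ccc1C(CC)(CC)c1ccc(OCC(O)C(C)(C)C)c(C)c1`: 490 nM

Compound 3, at 490 nM, lies within the scatter of both other compounds, so these numbers set no order among them. Compound 4 `CCN(CC)CCCNC(=O)c1ccc(C(CC)(CC)c2ccc(OCC(O)C(C)(C)C)c(C)c2)n1CC` differs from compound 3 in one place: diethylamino in place of dimethylamino on a saturated chain carbon, three bonds along the chain from an amide-type nitrogen. In short, it has diethylamino in place of dimethylamino on a saturated chain carbon, three bonds along the chain from an amide-type nitrogen.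

Among the measured compounds shown here, only one measured step touches this part of the molecule, and it changes the chain rather than the amine: a 1.3-fold lower number from compound 2 to compound 3 (0.13 log units; within the scatter). It therefore bears on the change only indirectly. Compound 1 already carries 3-(diethylamino)propyl, with a carbonyl where compound 4 has a hydroxyl, and compound 1 gives 530 nM. On this evidence, no step beyond the scatter is expected in this assay. The expected step is a 1.0-fold higher number from compound 3 to compound 4 (0.01 log units; within the scatter). For compound 4 the estimated value is 500 nM, with an expected range of 250 nM to 1000 nM.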

Compound 4, half-maximal inhibitory concentration: 190 nM
Compound 4: the middle estimate sits 2.6-fold (0.42 log units) above what was measured, and the stated range ends above it.
By their numbers in this assay, from the lowest: compound 4; then compounds 3, 1 and 2 (each within the scatter of the next).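

In this assay, the amine at this place now counts: with the propyl chain held, diethylamino in place of dimethylamino gives a 2.6-fold lower number from compound 3 to compound 4 (0.41 log units; beyond the scatter), whereas the earlier chain step stayed within the scatter. The hydroxyl side of the molecule counts too, since 1-hydroxy-2,2-dimethylpropyl in place of (tert-butyl)carbonyl, with 3-(diethylamino)propyl present on both sides of the comparison, gives a 2.8-fold lower number from compound 1 to compound 4 (0.45 log units; beyond the scatter), and changing chain and amine together gives a 3.5-fold lower number from compound 2 to compound 4 (0.54 log units; beyond the scatter), which leaves compound 4 the strongest of the four. No measurement shown here accounts for these steps.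

The compounds shown leave open whether dipropylamino, or a pyrrolidine or morpholine ring, on the same chain would lower the number further. They also leave open whether 2-(diethylamino)ethyl would match 3-(diethylamino)propyl.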